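The source may report more compounds than this note shows. Statements on the series, on what has been measured and on what is new or still open speak of the compounds shown alone.

Compound 1 `C/C(=C\c1cc(-c2ccc(C)cc2)co1)C(N)=O` and compound 2 `C/C(=C\c1cc(-c2cccnc2)co1)C(N)=O` share one core and differ only in the aromatic group attached to it. In a functional assay on HeLa cells (Homo sapiens) for cytotoxicity, read by CCK-8 assay, with a stated time of 24 h (a higher number here means a weaker inhibitor, a lower number a stronger inhibitor), compound 1 gives 12000 nM. Compound 2, tested in this assay, gives > 50000 nM, which is a limit of the measurement and not a number. Compound 2 therefore stands at the limit of > 50000 nM in this assay, at which 1 of the 2 values shown sits, the weaker end of the two values shown, and no number for it is known. Compound 3 `C/C(=C\c1cc(-c2ccc(F)nc2)co1)C(N)=O` has not yet been measured; it differs from compound 2 by fluoro in place of hydrogen on an aromatic carbon. Among the compounds with values here, no step between two measured compounds shows how such a change acts in this assay, so the expected step is a number no higher from compound 2 to compound 3 (the limit leaves the size open), none beyond the usual scatter. For compound 3 in this assay the expected value is 50000 nM, within 20000 nM to 120000 nM, and it is likely that only a limit will be reported for compound 3.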

Compound 3, half-maximal inhibitory concentration: > 50000 nM
Compound 3: only a limit was reported; the forecaster's own chance of this, stated with the estimate: 70%; the middle value sits exactly at the limit.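

Compound 3 gives > 50000 nM in this assay and this is a limit, not a number. Within the data shown here, compound 2 also stands only at a limit, so no step from compound 2 to compound 3 can be read: the limit of > 50000 nM in this assay, at which 2 of the 3 values shown sit. The compounds shown leave open what numbers this assay would give for compound 2 and compound 3, and so how fluoro in place of hydrogen on an aromatic carbon acts.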